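Agonist activity of a piperazinyl series: compound 4 expected

The compounds below may be only part of what the source reports. "The series", "measured", "known", "first", "only" and "open" are said of these compounds alone.

Compound 1 `CN(C[C@@H]1Cc2c(cccc2N2CCNCC2)CN1)[C@H]1CCCc2cccnc21`. In a functional assay on CCRF-CEM cells for agonist activity at C-X-C chemokine receptor type 4 (Homo sapiens), read by calcium flux, with a stated time of 25 min (a higher number here means that more compound is needed for the effect, a lower number that less compound is needed), compound 1 gives > 30000 nM, which is a limit of the assay.
Compound 2 `CN(C[C@H]1Cc2c(cccc2N2CCN(C3CC3)CC2)CN1)[C@H]1CCCc2cccnc21`. In this assay compound 2 gives > 30000 nM, again a limit.
Compound 3 `CN(C[C@H]1Cc2c(cccc2N2CCNC(C)(C)C2)CN1)[C@H]1CCCc2cccnc21`. In this assay compound 3 gives > 30000 nM, once more a limit.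

Compound 3 therefore stands only at a limit, as do the other two measured compounds. Within the data shown here, the single one-place step among them, a step that the two limits leave unreadable from compound 2 to compound 3, cannot be read because of the limit of > 30000 nM in this assay, at which 3 of the 3 values shown sit; no measured step gives a size at all.

The unmeasured compound 4 `CN(C[C@H]1Cc2c(cccc2N2CCN3CCC[C@H]3C2)CN1)[C@H]1CCCc2cccnc21` differs from compound 3 by a group of 9 heavy atoms (7 carbon, 2 nitrogen; one five-membered non-aromatic ring with 1 hetero atom, one six-membered non-aromatic ring with 2 hetero atoms) in place of a group of 8 heavy atoms (6 carbon, 2 nitrogen; one six-membered non-aromatic ring with 2 hetero atoms), on an aromatic carbon. The change alters the group on the aromatic carbon in the same region that the earlier exchanges touched, and none of those exchanges moved any compound off the limit. The measured steps thus bear on this one only in showing that such exchanges have produced nothing readable so far. No direction or size of step in this assay can be expected from them beyond the scatter.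

Compound 4 is consequently estimated to return a limit as well, at 50000 nM, with a range of 20000 nM to 200000 nM; the implied step that the limit leaves unreadable from compound 3 to compound 4 is an expectation only.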

Compound 4, half-maximal effective concentration: > 30000 nM
Compound 4: no number, only a limit; the forecaster's own chance of this, stated with the estimate: 85%; the middle value is on the limit's open side.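

Neither the step from compound 3 to compound 4 nor the step from compound 2 to compound 4 can be read in this assay, because every value shown ends at the same point: the limit of > 30000 nM in this assay, at which 4 of the 4 values shown sit. The compounds shown leave open how far each lies from that limit, and whether any group on this aromatic carbon gives a readable agonist effect.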